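The source may hold more compounds than are shown below. What is called first, only, known or untested is meant among the compounds shown, and "the series" means these compounds.

Compound 3 `O=C(CCCCc1ccccc1)c1nc2ncccc2o1` stands lowest of the two numbers recorded in an assay on HEK-293T cells for inhibition of diacylglycerol lipase-alpha (Homo sapiens), read by colorimetric assay; a lower number here means a stronger inhibitor, a higher number a weaker inhibitor: compound 3 gives 204 nM. Compound 1 `O=C(CCCCCCc1ccccc1)c1nc(Cl)co1` gives 2400 nM. For compound 2 `O=C(CCCCCCc1ccccc1)c1nc(Br)co1` the assay returns only a limit, > 10000 nM. Among the measured compounds shown here, the single measured step, an at least 4.1-fold higher number from compound 1 to compound 2 (0.61 log units; beyond the scatter), concerns a halogen swap on the ring of the core and rests on the limit (the limit of > 10000 nM in this assay, at which 1 of the 3 values shown sits); it does not touch the chain end that changes here. Compound 4 `CCCCCCCC(=O)c1nc2ncccc2o1` differs from compound 3 by propyl in place of phenyl on a saturated chain carbon, four bonds along the chain from a carbonyl carbon. For the measured compounds named here, no measured pair bears on this change, so the estimate rests on compound 3 alone. Compound 4 is expected to give a somewhat higher number, the step being a 2.9-fold higher number from compound 3 to compound 4 (0.47 log units; beyond the scatter). Compound 4 is estimated at 600 nM, with a range from 150 nM to 3000 nM.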

Compound 4, half-maximal inhibitory concentration: 631 nM
For compound 4 the middle estimate is 1.1-fold (0.02 log units) below the measured one; low and high end bracket the measured number.
By their numbers in this assay, from the lowest: compound 3; then compound 4; then compound 1. At a limit, above all of these: compound 2.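

At the chain end, on a saturated chain carbon, four bonds along the chain from a carbonyl carbon, propyl in place of phenyl gives a modest change, a 3.1-fold higher number from compound 3 to compound 4 (0.49 log units; beyond the scatter), the first step read at this position. The compound without a ring at the chain end, compound 4, still gives a measured number and not a limit. Nothing shown accounts for the size of this step. Open, as far as these compounds go, is how a longer chain, a cyclohexyl group or a terminal amine would read at this end. Also open, from the compounds shown here alone, is whether the same change carries over to the halogen-bearing core of compound 1.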